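Shrinking the amide nitrogen substituent of a thiazolidinedione

This account rests on a few compounds, and the source may have more. Where it says the series, first, only, none or still open, it means among the compounds named here.

Among the measured compounds shown here, compound 2 `Nc1ccc(/C=C2\SC(=O)N(Cc3cccc(Cl)c3)C2=O)cc1` stands lowest of the two numbers so far in a functional assay on FM3A cells (Mus musculus) for cytotoxicity, read by cell counting, with a stated time of 2 days; on this read-out lower numbers stand for stronger inhibition and higher numbers for weaker inhibition; compound 1 `Nc1ccc(/C=C2\SC(=O)N(Cc3ccccc3)C2=O)cc1` gives 24000 nM, and compound 2 gives 10000 nM. Compound 3 `CCN1C(=O)S/C(=C\c2ccc(N)cc2)C1=O` differs from compound 2 by methyl in place of 3-chlorophenyl on a saturated chain carbon bound to an amide-type nitrogen in a ring. For the measured compounds named here, the only measured step that bears on this is a 2.4-fold lower number from compound 1 to compound 2 (0.38 log units; beyond the scatter), where adding chloro to the aromatic ring helped modestly; here the whole ring, chloro included, is removed, so a higher number is expected, likely larger than that step. Compound 3 is therefore expected to give 40000 nM (range 12000 nM to 130000 nM), a step of a 4.0-fold higher number from compound 2 to compound 3 (0.60 log units; beyond the scatter).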

Compound 3, half-maximal inhibitory concentration: 76000 nM
For compound 3 the middle estimate is 1.9-fold (0.28 log units) below the measured one; the range from low to high includes it.
By their numbers in this assay, from the lowest: compound 2; then compound 1; then compound 3.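

In this assay, methyl in place of 3-chlorophenyl gives a 7.6-fold higher number from compound 2 to compound 3 (0.88 log units; beyond the scatter) on this saturated chain carbon, and methyl in place of phenyl gives a 3.2-fold higher number from compound 1 to compound 3 (0.50 log units; beyond the scatter) with no chloro involved. The aromatic ring therefore matters here apart from its chloro, and among these compounds the number rises as the substituent shrinks. Nothing at hand gives a reason for this. The compounds shown leave open whether a butyl chain or a cyclohexyl ring would hold the lower numbers, which would separate the aromatic ring from plain size.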